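The source may hold more compounds than are shown below. What is called first, only, known or untested is meant among the compounds shown, and "the series" means these compounds.

Working notes on the series. Among the compounds with values here, compound 1 `C=CCOc1ccccc1C1CC(=O)c2ccccc2O1` carries the shared core; in a functional assay on J774.A1 cells (Mus musculus) for inhibition, read by Griess assay, with stated times of 1 h and 24 h (a higher number here means a weaker inhibitor, a lower number a stronger inhibitor), compound 1 gives 38600 nM, the highest of the three numbers measured so far. Compound 2 `CC(C)=CCOc1ccccc1C1CC(=O)c2ccccc2O1` gives 34300 nM and compound 3 `CC(C)c1ccc(COc2ccccc2C2CC(=O)c3ccccc3O2)cc1` gives 28600 nM. The step of a 1.1-fold lower number from compound 1 to compound 2 (0.05 log units; within the scatter) and the step of a 1.3-fold lower number from compound 1 to compound 3 (0.13 log units; within the scatter) both lie within the scatter, as does a 1.2-fold lower number from compound 2 to compound 3 (0.08 log units; within the scatter); across these three compounds the group on the saturated chain carbon bound to an oxygen on the aromatic ring has moved the number only within the scatter.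

Compound 4 `CC(C)COc1ccccc1C1CC(=O)c2ccccc2O1` is not yet measured. It differs from compound 1 by isopropyl in place of vinyl on a saturated chain carbon bound to an oxygen on an aromatic ring. Within the data shown here, the steps that bear on it are a 1.1-fold lower number from compound 1 to compound 2 (0.05 log units; within the scatter) and a 1.3-fold lower number from compound 1 to compound 3 (0.13 log units; within the scatter), where vinyl was exchanged for other groups at the same place without a step beyond the scatter. Among the measured compounds shown here, the change to isopropyl removes the double bond outside aromatic rings at that place, and no measured step tests that on its own. Nothing in the series points to a step beyond the scatter, so compound 4 is expected close to compound 1, with a 1.0-fold lower number from compound 1 to compound 4 (0.01 log units; within the scatter) expected to stay within the scatter. For compound 4 the estimate in this assay is 38000 nM, with a range from 19000 nM to 76000 nM.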

Compound 4, half-maximal inhibitory concentration: 33200 nM
Beside the measured number, compound 4's estimate is 1.1-fold (0.06 log units) above it; low and high end bracket the measured number.
By their numbers in this assay, from the lowest: compounds 3, 4, 2 and 1 (each within the scatter of the next).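

In this assay, the change from allyl to isobutyl removes the double bond outside aromatic rings at this place, and the step of a 1.2-fold lower number from compound 1 to compound 4 (0.07 log units; within the scatter) shows that this exchange, with its larger saturated group, does not move the number beyond the scatter. The other two steps agree, with a 1.2-fold higher number from compound 3 to compound 4 (0.06 log units; within the scatter) against the aromatic group and a 1.0-fold lower number from compound 2 to compound 4 (0.01 log units; within the scatter) against the other unsaturated group, so among these four compounds neither a double bond outside aromatic rings nor the ring of the 4-isopropylphenyl group is needed on the saturated chain carbon bound to an oxygen on an aromatic ring to keep the number within the scatter of the others. No measurement on these compounds offers an account of why the number stays so flat at this place.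

The groups shown at this place are all built of carbon and hydrogen and carry no net charge, which leaves open whether an amine, a carboxylic acid or a hydroxyl group on the chain would give a step beyond the scatter. Also open, from the compounds shown here alone, is what a methoxy group or a fluorine placed elsewhere on the shared core would do to the number.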